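This account rests on a few compounds, and the source may have more. Where it says the series, first, only, none or still open, it means among the compounds named here.

Compound 1 `CC(C)c1cn2ccccc2c1S(=O)(=O)c1ccc(OCCCN2CCN(c3ccccc3)CC2)cc1`: 205 nM
Compound 2 `CCCCN(CCCC)CCCCOc1ccc(S(=O)(=O)c2c(C(C)C)cn3ccccc23)cc1`: 20.2 nM

In a functional assay (aorta) with Rattus norvegicus as the target (a higher number here means a weaker inhibitor, a lower number a stronger inhibitor), compound 2 has the lower of the two numbers, which makes it the stronger inhibitor of this pair. For the measured compounds named here, only one measured step is available, a 10-fold lower number from compound 1 to compound 2 (1.01 log units; beyond the scatter), and it is large and beyond the scatter. In that step, (dibutylamino)methyl replaced 4-phenylpiperazin-1-yl at the same place on the chain.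

Compound 3 `CCN(CC)CCCOc1ccc(S(=O)(=O)c2c(C(C)C)cn3ccccc23)cc1` is changed at that place again: diethylamino in place of (dibutylamino)methyl on a saturated chain carbon, three bonds along the chain from an oxygen on an aromatic ring. Here diethylamino stands in place of (dibutylamino)methyl. This step bears only indirectly, since it involved a different pair of groups. Like compound 2, compound 3 carries no ring in this group, so the starting point for the expectation is compound 2 at 20.2 nM, with some loss expected from the smaller group. The expected change is a 2.2-fold higher number from compound 2 to compound 3 (0.35 log units; beyond the scatter), towards a higher number, though it is uncertain. For compound 3 the estimate is 45 nM, with an expected range of 12 nM to 170 nM.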

Compound 3, half-maximal inhibitory concentration: 228 nM
Beside the measured number, compound 3's estimate is 5.1-fold (0.70 log units) below it; measured number outside the range, above it.
By their numbers in this assay, from the lowest: compound 2; then compounds 1 and 3 (each within the scatter of the next).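

In this assay, putting diethylamino in place of (dibutylamino)methyl gives an 11-fold higher number from compound 2 to compound 3 (1.05 log units; beyond the scatter) and so shows that this position responds strongly even when neither group contains a ring. The ring of 4-phenylpiperazin-1-yl does not by itself separate these compounds, since putting diethylamino in its place gives a 1.1-fold higher number from compound 1 to compound 3 (0.05 log units; within the scatter) and only compound 2 stands apart among the three. Nothing available explains why these groups give these numbers.

This change also swaps butyl for ethyl and removes the methyl link, so the two alterations cannot be told apart. The compounds shown leave open whether dibutylamino on the shorter chain of compound 3, or diethylamino on the longer chain of compound 2, would carry the difference, and where an intermediate dipropylamino group would fall.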